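A few compounds are considered here, and "the series" means these few. Any claim that something is new, unique, unknown or untested is made for them only; others in the source may bear on it.

Compound 1 `CNC(=O)c1cc(C(=O)NC2CC2)cn(Cc2ccc3nc[nH]c3c2)c1=O` gives 1.2 in a physicochemical assay for lipophilicity, at pH 7.4; a higher number here means a more lipophilic compound, a lower number a more polar compound.
Compound 2 `CNC(=O)c1cc(C(=O)NC2CC2)cn(Cc2cccc(C#N)c2)c1=O` gives 2.6 in this assay.
Compound 3 `CNC(=O)c1cc(C(=O)NC2CC2)cn(Cc2cccc(F)c2)c1=O` gives 3.2 in this assay.

Among the three compounds measured in this assay, compound 3 stands highest. Its nearest neighbour is compound 2, separated by the step of a number 0.60 log units higher from compound 2 to compound 3 (beyond the scatter); the furthest is compound 1, separated by the step of a number 2.00 log units higher from compound 1 to compound 3 (beyond the scatter). The unmeasured compound 4 `CNC(=O)c1cc(C(=O)NC2CC2)cn(Cc2cccc3occc23)c1=O` differs from compound 3 in a single place: 1-benzofuran-4-yl in place of 3-fluorophenyl on a saturated chain carbon bound to an aromatic nitrogen.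

Within the data shown here, two measured steps bear on this change, though neither matches it exactly. The large step of a number 2.00 log units higher from compound 1 to compound 3 (beyond the scatter) shows how strongly the read-out in this assay moved when the 1H-benzimidazol-6-yl group was exchanged for 3-fluorophenyl; the modest step of a number 0.60 log units higher from compound 2 to compound 3 (beyond the scatter) shows the smaller movement between cyano and fluoro on an aromatic carbon. The 1-benzofuran-4-yl group that enters in compound 4 carries a single hydrogen-bond acceptor and no donor, so the dramatic shift seen between compound 1 and compound 3 is not expected to repeat. A small upward step is expected instead, at the edge of the usual scatter, described by a number 0.20 log units higher from compound 3 to compound 4 (within the scatter). Compound 4 is therefore estimated at 3.4 in this assay, within a range from 2.9 to 3.9.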

Compound 4, distribution coefficient: 3.4
The estimate for compound 4 equals the measured number at the digits printed; the measured number falls inside the stated range.
By their numbers in this assay, from the lowest: compound 1; then compound 2; then compounds 3 and 4 (each within the scatter of the next).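

In this assay the exchange of 3-fluorophenyl for 1-benzofuran-4-yl, with 9 heavy atoms in place of 7 and 1 hydrogen-bond acceptor in place of 0, gives the step of a number 0.20 log units higher from compound 3 to compound 4 (within the scatter), so at this place on a saturated chain carbon bound to an aromatic nitrogen the two groups cannot be told apart by this read-out. Before this result, the only group with two aromatic rings at this place was the 1H-benzimidazol-6-yl of compound 1, which held the lowest number; the step of a number 2.20 log units higher from compound 1 to compound 4 (beyond the scatter) now shows that two such rings do not by themselves go with a low number, and the step of a number 0.80 log units higher from compound 2 to compound 4 (beyond the scatter) places 1-benzofuran-4-yl clearly above 3-cyanophenyl as well. Nothing available accounts for these steps.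

Going by these compounds, all four compounds share one core and differ only at this place, so it remains open how far the read-out would move with an amine or a carboxylic acid on the 1-benzofuran-4-yl group. On these data alone, it is equally open whether a longer chain carrying that group would leave the number where compound 4 stands.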